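The source may hold more compounds than are shown below. What is called first, only, known or untested is meant among the compounds shown, and "the series" means these compounds.

Measured compounds in a functional assay on CHO cells for agonist activity at Alpha-2C adrenergic receptor (Homo sapiens); a higher number here means a larger maximal response, a lower number a smaller maximal response:
compound 1, `Cc1ccc(-c2ccccc2OC(C)C2=NCCN2)cc1`: 0.46
compound 2, `CC(Oc1ccccc1-c1ccccc1)C1=NCCO1`: < 0.3, a limit of the assay, not a number
compound 3, `CC(Nc1ccccc1-c1ccccc1)C1=NCCN1`: 0.7

Compound 1 is the lower of the two numbers in this assay; compound 3 sits a step higher that is beyond the scatter of repeats. One further compound contributes only a limit, as the limit of < 0.3 in this assay, at which 1 of the 3 values shown sits, records.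

Compound 4, `CC(Oc1ccccc1-c1cccs1)C1=NCCN1`, is not yet measured in this assay. It differs from compound 1 at one place: thiophen-2-yl in place of 4-methylphenyl on an aromatic carbon. Going by the values given here, no measured pair isolates this change, so the size of the step is open; a modest move in either direction, or none beyond the scatter, seems about as likely. Compound 4 is expected near 0.5, between 0.3 and 0.7, a step of a number 0.040 higher from compound 1 to compound 4 (within the scatter).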

Compound 4, intrinsic activity: the largest response reached, as a fraction of the reference agonist's: 0.8
Estimate against measurement, compound 4: 0.30 below; measured number outside the range, above it.
By their numbers in this assay, from the lowest: compound 1; then compounds 3 and 4 (each within the scatter of the next). At a limit, below all of these: compound 2.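

In this assay, the aromatic carbon ortho to a group of 8 heavy atoms proves sensitive to the ring it carries: thiophen-2-yl in place of 4-methylphenyl gives a number 0.34 higher from compound 1 to compound 4 (beyond the scatter). Going by these compounds alone, this is the first one-place change, and it shows that maximal response can move substantially at this position. Nothing at hand accounts for the size of the step.

A single pair cannot separate the loss of the methyl group from the change of ring. Going by these compounds, how furan-2-yl or an aminomethyl group would behave at this position remains open.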